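The source may hold more compounds than are shown below. What is called first, only, known or untested is meant among the compounds shown, and "the series" means these compounds.

Compound 1, with the structure `COc1ccc2c(=O)c(/C=C/C(=O)Nc3cccc(C)c3)coc2c1`, carries a methyl group on the aniline ring of a shared core. In a functional assay (QGY7701 cells, Homo sapiens) for inhibition, read by MTT assay, with a stated time of 48 h (on this read-out higher numbers stand for weaker inhibition and lower numbers for stronger inhibition), compound 1 reaches only a limit, > 100000 nM, and no number. Compound 2, with the structure `COc1ccc2c(=O)c(/C=C/C(=O)Nc3ccccc3)coc2c1`, differs from it by a hydrogen in place of that methyl on an aromatic carbon. In this assay, within the data shown here, compound 2 gives 14000 nM, the only number among the values shown. Among the measured compounds shown here, the step of an at least 7.1-fold lower number from compound 1 to compound 2 (0.85 log units; beyond the scatter) is the sole measured step, and it rests on a limit (the limit of > 100000 nM in this assay, at which 1 of the 2 values shown sits).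

Compound 3, with the structure `COc1ccc2c(=O)c(/C=C/C(=O)Nc3ccccc3Cl)coc2c1`, takes the next step from compound 2: chloro in place of hydrogen on an aromatic carbon. For the measured compounds named here, no measured step touches a chloro group or this place on the ring, so the one step from compound 1 to compound 2, which shows only that the removal of a substituent helped, gives a weak guide. The estimate for compound 3 in this assay is therefore placed near compound 2, at 20000 nM, with a range from 5000 nM to 100000 nM, which corresponds to an expected step of a 1.4-fold higher number from compound 2 to compound 3 (0.15 log units; within the scatter).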

Compound 3, half-maximal inhibitory concentration: 23000 nM
Compound 3: the middle estimate sits 1.2-fold (0.06 log units) below what was measured; the range from low to high includes it.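

In this assay, compound 3 gives the first substituted ring on the shared core that can be read as a number on both sides of a step, and the step of a 1.6-fold higher number from compound 2 to compound 3 (0.22 log units; within the scatter) does not separate chloro from hydrogen at this place, ortho to a large group. A substituent on this ring is therefore not enough on its own to reach the limit seen for compound 1, at least where that substituent is a chloro group at this place. The step of an at least 4.3-fold lower number from compound 1 to compound 3 (0.63 log units; beyond the scatter) exchanges 3-methylphenyl for 2-chlorophenyl, so group and place differ together, and its size is only a bound that rests on a limit: the limit of > 100000 nM in this assay, at which 1 of the 3 values shown sits.

The compounds shown leave open whether the gap between compound 1 and compound 3 belongs to the group or to its place, as none of them carries a methyl group where compound 3 has its chloro group, or a chloro group where compound 1 has its methyl group. They also leave open how a fluoro group, a methoxy group, an amine or a carboxylic acid would read at this place, and whether any of these would move beyond the scatter of compound 2.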